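Melanin-concentrating hormone receptor 1 series: amide variation on compound 3

The source may hold more compounds than are shown below. What is called first, only, known or untested is meant among the compounds shown, and "the series" means these compounds.

Measured so far:
compound 1, `O=C(CN1CCN(Cc2ccn(-c3ccc(C(F)(F)F)cn3)c2)CC1)NC(c1ccc(F)cc1)c1ccc(F)cc1`, 55 nM
compound 2, `COCC(O)CN(Cc1ccc(F)cc1)C(=O)CC1CCN(Cc2ccc(-c3ccc(Cl)cc3)o2)CC1`, 150 nM
compound 3, `O=C(CC1CCN(Cc2ccc(-c3ccc(Cl)cc3)o2)CC1)NCC(O)C(F)(F)F`, 815 nM

All three were tested in an assay on HEK293 cells for displacement of a labelled ligand from melanin-concentrating hormone receptor 1 (Homo sapiens); a lower number here means a stronger inhibitor, a higher number a weaker inhibitor. Compound 3 gives the highest of the three numbers in this assay. The nearest number is that of compound 2, which gives 150 nM; the furthest is that of compound 1, which gives 55 nM. Both gaps lie beyond the usual scatter, so compound 3 is the weakest of the three measured compounds.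

The next compound, compound 4, is `O=C(CC1CCN(Cc2ccc(-c3ccc(Cl)cc3)o2)CC1)N1CCCC(CO)C1`. It keeps the core of compound 3 and differs only at the amide: 3-(hydroxymethyl)piperidin-1-yl in place of (3,3,3-trifluoro-2-hydroxypropyl)amino on a carbonyl carbon. The open-chain secondary amide is thus exchanged for a ring-closed tertiary amide carrying a single hydroxyl donor. Among the compounds with values here, no measured pair isolates this exchange, so its size can only be expected, not read off. Compound 2, the other tertiary amide of the set, gives 150 nM on the same core, which points towards a lower number for compound 4 than for compound 3, of modest size. The expected step is a 2.7-fold lower number from compound 3 to compound 4 (0.43 log units; beyond the scatter). Compound 4 is estimated at 300 nM, with a range from 100 nM to 900 nM.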

Compound 4, half-maximal inhibitory concentration: 597 nM
For compound 4 the middle estimate is 2.0-fold (0.30 log units) below the measured one, within the range that was stated.
By their numbers in this assay, from the lowest: compound 1; then compound 2; then compounds 4 and 3 (each within the scatter of the next).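

In this assay the exchange at this amide gives a 1.4-fold lower number from compound 3 to compound 4 (0.14 log units; within the scatter), so (3,3,3-trifluoro-2-hydroxypropyl)amino and 3-(hydroxymethyl)piperidin-1-yl on a carbonyl carbon read alike in this pair. Going from the open-chain secondary amide to the ring-closed tertiary amide, with the three fluorine atoms gone, thus leaves the number within the scatter, and being a tertiary amide on this core is not enough to match compound 2, which gives 150 nM, while compound 4 gives 597 nM on the same core. No measurement at hand bears on why the two groups read alike.

Still open is whether the number of compound 2 goes with its fluorobenzyl group, its methoxy-bearing hydroxypropyl chain or both, since neither is varied alone in the compounds shown. Also open, from the compounds shown here alone, is whether the ring of compound 4 tolerates a carboxylic acid or a primary amine in place of its hydroxymethyl group, or whether the number then moves beyond the scatter.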